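Chloro added to the benzoyl ring of compound 1

A few compounds are considered here, and "the series" means these few. Any claim that something is new, unique, unknown or untested is made for them only; others in the source may bear on it.

Compound 1 `Nc1scc(-c2ccc3ccccc3c2)c1C(=O)c1ccccc1` and compound 2 `Nc1scc(-c2ccc(Br)cc2)c1C(=O)c1ccc(Cl)cc1` share the same core. For the measured compounds named here, in a functional assay on CHO cells for agonist activity at adenosine receptor A1 (Homo sapiens), read by fluorescence and ERK phosphorylation, with stated times of 30 min and 1.5 h, tested at 10 uM (a lower number here means a weaker effect, a higher number a stronger effect of the compound at the concentration tested), compound 1 gives 73%, the higher of the two numbers measured so far. In this assay compound 2 gives 46%, which falls beyond the usual scatter below compound 1. Going by the values given here, compound 1 and compound 2 differ in two places at once, so their two values show only that the doubly changed compound reads lower; no single step can be read from them.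

Compound 3 `Nc1scc(-c2ccc3ccccc3c2)c1C(=O)c1ccc(Cl)cc1` takes one of those two changes alone: chloro in place of hydrogen on an aromatic carbon. Because compound 2 carries this chloro together with a second change and gives 46%, a loss is expected in this assay, though smaller than the gap between compound 1 and compound 2, with the expected step being a number 11 percentage points lower from compound 1 to compound 3 (beyond the scatter). For compound 3 in this assay the estimate is 62%, with a range from 42% to 80%.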

Compound 3, a percentage reported as activity, at one concentration (the size of the read-out at that concentration, not a potency): 67%
For compound 3 the middle estimate is 5 percentage points below the measured one; the measured number falls inside the stated range.
By their numbers in this assay, from the lowest: compound 2; then compounds 3 and 1 (each within the scatter of the next).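

In this assay the step is a number 6 percentage points lower from compound 1 to compound 3 (within the scatter), so on this evidence chloro and hydrogen cannot be told apart at this place on the benzoyl ring, para to the large group. Phenyl to 4-chlorophenyl is therefore tolerated in the setting of compound 3, and the chloro alone does not reproduce the lower reading of compound 2, which now points to its second change, though that change has no step of its own here. No available evidence explains this result.

Whether a methoxy group, an amine or a carboxylic acid at the same place would also read alike remains open, since chloro is the only replacement for hydrogen shown there. Also open, from the compounds shown here alone, is how much of the value of compound 2, 46%, would remain with the second change alone.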